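The source may hold more compounds than are shown below. What is called first, only, known or untested is meant among the compounds shown, and "the series" means these compounds.

Measured so far in an ADME assay on BE(2)-C cells (Homo sapiens) for cytotoxicity, read by MTT assay, with a stated time of 72 h; a higher number here means a weaker inhibitor of growth, a lower number a stronger inhibitor of growth:
compound 1 `CCCCNC(=O)C1C(C(=O)O)[C@@H]2CC[C@H]1O2` gives 10000 nM
compound 2 `O=C(O)CCCNC(=O)C1C(C(=O)O)[C@@H]2CC[C@H]1O2` gives 10000 nM
compound 3 `O=C(O)CCCCCCCNC(=O)C1C(C(=O)O)[C@@H]2CC[C@H]1O2` gives 10000 nM

Compounds 1, 2 and 3 share one core and differ only in the chain on the amide nitrogen. Compound 2 to compound 1 is methyl in place of carboxy on a saturated chain carbon, three bonds along the chain from an amide-type nitrogen; the step is no change at the digits printed from compound 2 to compound 1 (within the scatter). Compound 2 to compound 3 is 4-carboxybutyl in place of carboxy on a saturated chain carbon, three bonds along the chain from an amide-type nitrogen, and the step is no change at the digits printed from compound 2 to compound 3 (within the scatter); compound 1 to compound 3 gives no change at the digits printed from compound 1 to compound 3 (within the scatter). Nothing in this set moves this assay.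

Compound 4 `CCCCCCCCNC(=O)C1C(C(=O)O)[C@@H]2CC[C@H]1O2` is not yet measured. From compound 3 it is methyl in place of carboxy on a saturated chain carbon, seven bonds along the chain from an amide-type nitrogen. This is the same kind of change as compound 2 to compound 1, but the place differs: three bonds along the chain from the amide-type nitrogen there, seven bonds here. The cores of compound 3 and compound 2 differ as given by 4-carboxybutyl in place of carboxy on a saturated chain carbon, three bonds along the chain from an amide-type nitrogen.

For compound 4 the expected step is no change at the digits printed from compound 3 to compound 4 (within the scatter), resting on no change at the digits printed from compound 2 to compound 1 (within the scatter), where the same kind of change left this assay flat, and on the unchanged values of all three measured compounds. Compound 4 is therefore estimated at 10000 nM, with a likely range from 5000 nM to 20000 nM.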

Compound 4, concentration for 50% growth inhibition: 10000 nM
Beside the measured number, compound 4's estimate shows no gap at the digits printed; measured number inside the range.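

In this assay, methyl in place of carboxy, seven bonds along the chain from the amide-type nitrogen, gives no change at the digits printed from compound 3 to compound 4 (within the scatter); the other two steps read alike, with no change at the digits printed from compound 2 to compound 4 (within the scatter) and no change at the digits printed from compound 1 to compound 4 (within the scatter). The same change therefore reads the same on both cores: the same change on two cores in this assay, no change at the digits printed (within the scatter) from compound 2 to compound 1 and no change at the digits printed (within the scatter) from compound 3 to compound 4, 1.0-fold (0.00 log units) apart, within the scatter of two such steps

This agreement is only between two flat steps, with all four compounds level at the digits printed, so it does not show that the change would carry over to a core on which this assay moves, and it gives no order among the chains.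

Still open, on these data alone, is whether any other group on the amide nitrogen would move this assay at all, such as an amine in place of carboxy, a phenyl ring or a longer chain. Also open, as far as these compounds go, is whether an ester in place of the carboxy on the shared core would leave these values level.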